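The source may hold more compounds than are shown below. What is called first, only, known or untested is meant among the compounds shown, and "the series" means these compounds.

The three measured compounds share one core, an aminophenyl benzamide linked through a thioester to a thiocarbamate nitrogen, and differ only in what sits on that nitrogen. Compound 2 `CN(Cc1cccnc1)C(=S)SCc1ccc(C(=O)Nc2ccccc2N)cc1` carries a methyl and a pyridinylmethyl there, and in a functional assay on MGC-803 cells (Homo sapiens) for antiproliferative activity, read by CCK-8 assay, with a stated time of 72 h, tested at 2 uM (a lower number here means a weaker effect, a higher number a stronger effect of the compound at the concentration tested), compound 2 gives 45.9%, the highest of the three numbers. Compound 1 `Nc1ccccc1NC(=O)c1ccc(CSC(=S)N2CCc3ccc([N+](=O)[O-])cc32)cc1` closes the nitrogen into a nitro-substituted bicyclic ring, and in this assay compound 1 gives 30.6%. Compound 3 `Nc1ccccc1NC(=O)c1ccc(CSC(=S)N2CCN(Cc3ccncc3)CC2)cc1` uses a piperazine bearing a pyridinylmethyl group, and in this assay compound 3 gives 18.4%. Both of these stand below compound 2 by more than the scatter.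

Compound 4 `CN(C(=S)SCc1ccc(C(=O)Nc2ccccc2N)cc1)c1cccnc1` has not been measured. It differs from compound 2 in one place: pyridin-3-yl in place of (pyridin-3-yl)methyl on an amide-type nitrogen. For the measured compounds named here, no measured pair shows this change, so the size of its effect is unknown; a small step downward, possibly within the scatter, is the expectation here. The step from compound 2 to compound 4 is estimated at a number 5.9 percentage points lower from compound 2 to compound 4 (within the scatter). For compound 4 the estimated value in this assay is 40%, with a likely range from 22% to 58%.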

Compound 4, a percentage reported as inhibition, at one concentration (the size of the read-out at that concentration, not a potency): 46.1%
Estimate against measurement, compound 4: 6.1 percentage points below; the range from low to high includes it.
By their numbers in this assay, from the lowest: compound 3; then compound 1; then compounds 2 and 4 (each within the scatter of the next).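

With pyridin-3-yl in place of (pyridin-3-yl)methyl on the amide-type nitrogen, this assay gives a number 0.2 percentage points higher from compound 2 to compound 4 (within the scatter) in the only single-place comparison shown. At this position, the pyridine ring attached directly to the nitrogen and the same ring attached through the methyl link cannot be told apart by this read-out at the concentration tested. Nothing measured here bears on why the two groups read alike.

The compounds shown leave open whether the same holds for a longer chain such as 2-(pyridin-3-yl)ethyl, or for pyridin-4-yl or phenyl on the same nitrogen. Also open, on these data alone, are whether the methyl on that nitrogen could give way to an ethyl, and whether compound 2 and compound 4 would separate in a full potency measurement.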